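Naphthyloxyacetyl Hydrazones: Moving the Hydroxyl on the Phenyl Ring

A few compounds are considered here, and "the series" means these few. Any claim that something is new, unique, unknown or untested is made for them only; others in the source may bear on it.

Compound 1 `O=C(COc1cccc2ccccc12)N/N=C/c1ccc(O)cc1` — in an ADME assay on HEL cells (Homo sapiens) for cytotoxicity (on this read-out lower numbers stand for higher toxicity in this test and higher numbers for lower toxicity in this test), compound 1 gives 60.6 ug/mL.
Compound 2 `COc1ccc(/C=N/NC(=O)COc2cccc3ccccc23)cc1OC` — in this assay compound 2 gives 52.6 ug/mL.

Both measured compounds share the same core and differ only in the substituted phenyl ring attached to the carbon with a double bond to nitrogen. Among the measured compounds shown here, compound 1 has the highest of the two numbers, and the nearest is compound 2, whose number sits within the scatter of the one for compound 1. On these two values, then, the two compounds cannot be told apart in this assay.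

Compound 3 `O=C(COc1cccc2ccccc12)N/N=C/c1ccccc1O` has not yet been measured in this assay. It differs from compound 1 only in where the hydroxyl sits on the phenyl ring: 2-hydroxyphenyl in place of 4-hydroxyphenyl on a carbon with a double bond to nitrogen

For the measured compounds named here, no step between measured compounds is available for this kind of change, and the two measured values themselves lie within the scatter of each other. The account therefore expects no step beyond the scatter from compound 1 to compound 3, with a 1.1-fold lower number from compound 1 to compound 3 (0.04 log units; within the scatter) as the expected shift. For compound 3 the estimate in this assay is 55 ug/mL, in a range from 30 ug/mL to 110 ug/mL.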

Compound 3, half-maximal cytotoxic concentration: 3.57 ug/mL
Estimate against measurement, compound 3: 15-fold (1.19 log units) above; the whole stated range lies above it.
By their numbers in this assay, from the lowest: compound 3; then compounds 2 and 1 (each within the scatter of the next).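

Moving the hydroxyl, with the atoms of the compound otherwise unchanged, gives a 17-fold lower number from compound 1 to compound 3 (1.23 log units; beyond the scatter) in this assay, and on this read-out the lower number stands for higher toxicity in this test. Compounds 1 and 2 had shown only that two different substitution patterns on the phenyl ring can give values within the scatter of each other, whereas this pair shows that the phenyl ring on the carbon with a double bond to nitrogen is not indifferent to change: 2-hydroxyphenyl in place of 4-hydroxyphenyl is enough to produce a large step. The data shown hold nothing that explains why this one change has so large an effect.

The compounds shown leave open whether the step depends on the hydroxyl itself, a question that a methoxy group or an amine in place of the hydroxyl of the 2-hydroxyphenyl group would address. They also leave open whether the same step would appear on another core, such as one with a longer chain in place of the acetyl link, or in cells other than those of this assay.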